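The source may hold more compounds than are shown below. What is called first, only, known or untested is meant among the compounds shown, and "the series" means these compounds.

Compound 2 `Oc1cccc(-c2cc(-c3ccccc3)nc(-c3ccco3)c2)c1` is one of two compounds tested in an assay on isolated protein for inhibition of DNA topoisomerase 1 (Homo sapiens), with a stated time of 30 min, tested at 20 uM; on this read-out lower numbers stand for a weaker effect and higher numbers for a stronger effect at the one concentration tested. In this assay compound 2 gives 3.5%, the higher of the two numbers, while compound 1 `Oc1cccc(-c2cc(-c3ccccc3)nc(-c3ccsc3)c2)c1` gives 3.2%. These two values lie within the usual scatter of each other, so neither can be called more active than the other.

Compound 3 `Oc1cccc(-c2cc(-c3ccccc3)nc(-c3ccccn3)c2)c1` is not yet measured. It differs from compound 2 in one place: pyridin-2-yl in place of furan-2-yl on an aromatic carbon. Among the compounds with values here, the only measured step that bears on this change is the one between compound 1 and compound 2, where a change of a five-membered ring gave a number 0.3 percentage points higher from compound 1 to compound 2 (within the scatter). Swapping a five-membered aromatic ring for a six-membered one is a somewhat different kind of change, and no measured pair shows it, so the expectation rests only on the low level of both measured compounds. Compound 3 is therefore expected to stay near that level, with an expected step of a number 1.5 percentage points higher from compound 2 to compound 3 (within the scatter). The estimate for compound 3 in this assay is 5%, within a range from 0% to 15%.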

Compound 3, a percentage reported as inhibition, at one concentration (the size of the read-out at that concentration, not a potency): 2.8%
For compound 3 the middle estimate is 2.2 percentage points above the measured one, within the range that was stated.
By their numbers in this assay, from the lowest: compounds 3, 1 and 2 (each within the scatter of the next).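

In this assay, putting pyridin-2-yl in place of furan-2-yl gives a number 0.7 percentage points lower from compound 2 to compound 3 (within the scatter), and putting it in place of thiophen-3-yl gives a number 0.4 percentage points lower from compound 1 to compound 3 (within the scatter). Within the data shown here, the earlier pair compared only two five-membered aromatic rings, whereas these steps show that a six-membered aromatic ring with a ring nitrogen can also sit on this aromatic carbon, next to the ring nitrogen of the core, without setting the compound apart: compounds 1, 2 and 3 cannot be told apart by their numbers, and all remain low. No supporting measurement is available to explain why these three groups read alike.

All three groups at this position are aromatic rings with one hetero atom, so the compounds shown leave open whether a non-aromatic group here, such as an amine, a carboxylic acid or a longer alkyl chain, would give a clearly different number. They also leave open how the number would respond to a change in the phenyl or 3-hydroxyphenyl group, since both stay the same in all three compounds.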